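The source may report more compounds than this note shows. Statements on the series, on what has been measured and on what is new or still open speak of the compounds shown alone.

Measured so far:
compound 1, `Cc1c(C(=O)/C=C/c2ccc(Br)cc2)[n+]([O-])c2ccccc2[n+]1[O-]`, with 56000 nM
compound 2, `Cc1c(C(=O)/C=C/c2cccc([N+](=O)[O-])c2)[n+]([O-])c2ccccc2[n+]1[O-]`, with 122000 nM

Both compounds were tested in a functional assay on HSC-3 cells (Homo sapiens) for cytotoxicity, with a stated time of 48 h; a higher number here means that more compound is tolerated, a lower number that less compound is tolerated. Compound 1 gives 56000 nM there, and compound 2 gives 122000 nM. Of these two numbers, compound 1 has the lower one; the gap to compound 2 lies beyond the usual scatter, so compound 1 is the less tolerated of the pair, while compound 2 is the one of which more is tolerated.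

The step now followed leads from compound 1 to compound 3, `Cc1ccc(/C=C/C(=O)c2c(C)[n+]([O-])c3ccccc3[n+]2[O-])cc1`, which has not yet been measured in this assay. The change is methyl in place of bromo on an aromatic carbon. Among the measured compounds shown here, nothing among the measured pairs shows this exact exchange, so the size of the step cannot be read from the data; the expectation is that it stays small, most likely within the scatter, with no firm direction.

For compound 3 the estimated value in this assay is 65000 nM, with a range from 28000 nM to 150000 nM. The step this estimate means is a 1.2-fold higher number from compound 1 to compound 3 (0.06 log units; within the scatter), which is expected to be no more than the ordinary scatter.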

Compound 3, half-maximal cytotoxic concentration: 14000 nM
For compound 3 the middle estimate is 4.6-fold (0.67 log units) above the measured one; the measured number lies below the stated range.
By their numbers in this assay, from the lowest: compound 3; then compound 1; then compound 2.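

In this assay, the change from 4-bromophenyl to 4-methylphenyl gives a 4.0-fold lower number from compound 1 to compound 3 (0.60 log units; beyond the scatter) and so shows that this place, para to a large group, is sensitive: exchanging one heavy atom for another, with no change in the counted donors, acceptors or net charge, moves the number beyond the scatter. Among the compounds shown here, the direction is toward less compound being tolerated, and this could not be seen earlier, as compound 1 and compound 2 differ in more than one place and offered no step to read. No available data bear on why the exchange has this effect.

As far as these compounds go, whether other groups at this place, such as methoxy, chloro, an amine or a carboxylic acid, would give numbers nearer to compound 3 or to compound 1 remains open. The compounds shown also leave open whether a longer chain such as ethyl would move the number further than methyl does, and whether the same exchange would have a similar effect on another carbon of this ring.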